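Dichloroacetanilides on a Shared Core: Three Limits, One Forecast

A few compounds are considered here, and "the series" means these few. Any claim that something is new, unique, unknown or untested is made for them only; others in the source may bear on it.

Three dichloroacetamides sharing one core were tested in a functional assay on KB 3-1 cells (Homo sapiens) for cytotoxicity, read by MTT assay, with a stated time of 68 h; on this read-out lower numbers stand for stronger inhibition and higher numbers for weaker inhibition. Compound 1 `Cc1ccc(-c2cccc(NC(=O)C(Cl)Cl)c2)cc1` carries a methyl on its outer ring, compound 2 `O=C(Nc1cccc(-c2cccc(C(F)(F)F)c2)c1)C(Cl)Cl` carries a trifluoromethyl, and compound 3 `O=C(Nc1cccc(-c2ccc(C(F)(F)F)cc2)c1)C(Cl)Cl` carries a trifluoromethyl as well; the difference between the cores of compound 2 and compound 3 is not broken down here.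

In this assay compound 1 gives > 50000 nM, which is a limit of the assay and not a number. In this assay compound 2 gives > 50000 nM, also a limit. In this assay compound 3 gives > 50000 nM, again a limit.

The change from compound 3 to compound 1 is methyl in place of trifluoromethyl on an aromatic carbon. Its size reads a step that the two limits leave unreadable from compound 3 to compound 1, and that unreadability rests on (the limit of > 50000 nM in this assay, at which 3 of the 3 values shown sit).

Compound 4 `Cc1cccc(-c2cccc(NC(=O)C(Cl)Cl)c2)c1` has not yet been measured. It differs from compound 2 by methyl in place of trifluoromethyl on an aromatic carbon. This is the same kind of change as that from compound 3 to compound 1, but not the same: there the group sits para to a large group, here meta to a large group.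

With both neighbours of this change sitting at the limit described in the limit of > 50000 nM in this assay, at which 3 of the 3 values shown sit, the step from compound 2 to compound 4 is expected to be a number no higher from compound 2 to compound 4 (the limit leaves the size open). Compound 4 is therefore expected to give 50000 nM, most likely reported only as a limit, with a range from 20000 nM to 100000 nM.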

Compound 4, half-maximal inhibitory concentration: > 50000 nM
Compound 4 was reported as a limit; the forecaster's own chance of this, stated with the estimate: 80%; the middle value sits exactly at the limit.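

In this assay compound 4 gives > 50000 nM as a limit of the assay and not a number. Compound 2 sits at the same limit, so no new step can be read between compound 2 and compound 4: the limit of > 50000 nM in this assay, at which 4 of the 4 values shown sit.

The compounds shown leave open how far each lies past that limit, and whether any change to the shared core would give a readable value.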